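This account rests on a few compounds, and the source may have more. Where it says the series, first, only, none or still open, it means among the compounds named here.

In an ADME assay on S9 fraction (Rattus norvegicus) for metabolic stability, with a stated time of 60 min (on this read-out higher numbers stand for a more stable compound and lower numbers for a less stable compound), the measured compounds are these
compound 1 `O=c1[nH]c2ncc(-c3ccc(-c4nc[nH]n4)cc3)nc2n1CCC1CCOCC1` gives 93%
compound 2 `CC(C)(O)c1ccc(-c2cnc3c(n2)N(CCC2CCOCC2)C(=O)CN3)cn1` gives 73%

Compound 2 holds the lower of the two numbers, and the gap up to compound 1 lies beyond the scatter. Compound 3 `CO[C@H]1CC[C@H](N2C(=O)CNc3ncc(-c4ccc(C(C)(C)O)nc4)nc32)CC1`, not yet measured, carries 4-methoxycyclohexyl in place of 2-(oxan-4-yl)ethyl on an amide-type nitrogen in a ring. Among the measured compounds shown here, no measured pair shows this change, so the expected change in this assay is only a small rise, a number 7 percentage points higher from compound 2 to compound 3 (within the scatter) and possibly within the scatter. For compound 3 the estimate is 80% (expected range 62% to 95%).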

Compound 3, percent of the compound remaining: 81%
Compound 3: the middle estimate sits 1 percentage points below what was measured; the measured number falls inside the stated range.
By their numbers in this assay, from the lowest: compounds 2 and 3 (each within the scatter of the next); then compound 1.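

In this assay, putting 4-methoxycyclohexyl in place of 2-(oxan-4-yl)ethyl on an amide-type nitrogen in a ring gives a number 8 percentage points higher from compound 2 to compound 3 (within the scatter). This first one-place comparison shows that, on this core, a ring of carbon only and a ring with a hetero atom cannot be told apart at this position. Nothing available here explains this result. Still open, going by these compounds, is whether a plain methyl or a longer chain ending in an amine at this nitrogen would stand apart from both groups. On these data alone, the other stereoisomer of 4-methoxycyclohexyl also remains open.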